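Removing One Methyl Group: What One Precedent Suggests

The compounds below may be only part of what the source reports. "The series", "measured", "known", "first", "only" and "open" are said of these compounds alone.

Measured so far:
compound 1, `CSc1ccc2c(c1)c(O)c(C(=O)N(C)c1ccccc1)c(=O)n2C`: 100%
compound 3, `CNc1c(C(=O)N(C)c2ccccc2)c(=O)n(C)c2ccc(SC)cc12`: 83%
compound 2, `CSc1ccc2c(c1)c(N)c(C(=O)N(C)c1ccccc1)c(=O)n2C`: 22%

Of the compounds shown here, three sharing one core have been tested in a functional assay on the whole organism for inhibition, with Mus musculus as the target, at a dose of 32 mg/kg by the oral route; a higher number here means more inhibition at the dose given (going by the name of the read-out), a lower number less inhibition. Compound 1 stands highest: in this assay compound 1 gives 100%, and compound 3 gives 83%. The two cores differ in one place, (hydroxy in place of methylamino on an aromatic carbon), and the step of a number 17 percentage points lower from compound 1 to compound 3 (beyond the scatter) is modest. Compound 2 differs from compound 3 by hydrogen in place of methyl on a nitrogen on an aromatic ring; that single change produced a number 61 percentage points lower from compound 3 to compound 2 (beyond the scatter), a large loss. From compound 1 to compound 2, two places change at once, and a number 78 percentage points lower from compound 1 to compound 2 (beyond the scatter).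

Compound 4 `CSc1ccc2c(c1)c(O)c(C(=O)Nc1ccccc1)c(=O)n2C` has not yet been measured. It differs from compound 1 by hydrogen in place of methyl on an amide-type nitrogen. This is the same kind of change as from compound 3 to compound 2, but not the same change: there the nitrogen sits on an aromatic ring with only an aromatic carbon as its other neighbour, whereas here it is an amide-type nitrogen whose other neighbours are an aromatic carbon and a carbonyl carbon. Within the data shown here, the one precedent therefore carries limited weight.

Still, because a number 61 percentage points lower from compound 3 to compound 2 (beyond the scatter) was large, a loss from compound 1 to compound 4 is expected, estimated as a number 50 percentage points lower from compound 1 to compound 4 (beyond the scatter). Compound 4 is expected to give about 50%, with a plausible range from 10% to 95%.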

Compound 4, a percentage reported as inhibition, in the whole organism at one dose (the size of the read-out at that dose, not a potency): 24%
Compound 4: middle estimate off by 26 percentage points, on the high side, within the range that was stated.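

In this assay, putting hydrogen in place of methyl on the amide-type nitrogen gave a large loss, a number 76 percentage points lower from compound 1 to compound 4 (beyond the scatter), so the direction of the earlier change on the other nitrogen held on this core as well. Among these compounds, the size of the loss did not carry over exactly, and the two steps differ by more than ordinary scatter between repeated measurements: the same change on two cores in this assay, a number 61 percentage points lower (beyond the scatter) from compound 3 to compound 2 and a number 76 percentage points lower (beyond the scatter) from compound 1 to compound 4, 15 percentage points apart, beyond the scatter of two such steps This shows that, in these two pairs, losing that methyl goes with a large drop in inhibition at the dose given, but it rests on only two pairs, the two nitrogens are of different kinds, and a read-out at one dose gives the size of an effect rather than a potency, so it neither explains the drop nor predicts the size of the step on a further core.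

The compounds shown leave open whether ethyl or a longer chain on the amide-type nitrogen would keep the inhibition seen with methyl or lose it as hydrogen does. They also leave open whether the same step would stay as large with an amine or a carboxylic acid added to the phenyl group.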